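Replacing the indole of compound 1 with a methoxyphenyl group

The source may hold more compounds than are shown below. What is called first, only, known or untested is meant among the compounds shown, and "the series" means these compounds.

Compound 1, `Cc1ccc(S/C(=C/c2c[nH]c3ccccc23)C(=O)c2ccc(Br)cc2)cc1`, was tested in a functional assay on DU-145 cells (Homo sapiens) for inhibition, read by trypan blue exclusion, with a stated time of 96 h (a lower number here means a stronger inhibitor of growth, a higher number a weaker inhibitor of growth), where compound 1 gives 10000 nM. Compound 2, `Cc1ccc(S/C(=C/c2c[nH]c3ccccc23)C(=O)c2ccc(Cl)cc2)cc1`, gives 10000 nM in this assay, and the step of no change at the digits printed from compound 1 to compound 2 (within the scatter); compound 1 and compound 2 therefore stand level with each other, and together they hold the highest numbers of the three measured. Compound 3, `Cc1ccc(S/C(=C/c2c[nH]c3ccc(Cl)cc23)C(=O)c2ccc(Br)cc2)cc1`, gives 1000 nM, so the step of a 10-fold lower number from compound 1 to compound 3 (1.00 log units; beyond the scatter), which makes compound 3 the furthest from compound 1 in this assay.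

Compound 4, `COc1ccc(/C=C(/Sc2ccc(C)cc2)C(=O)c2ccc(Br)cc2)cc1`, differs from compound 1 as follows: 4-methoxyphenyl in place of 1H-indol-3-yl on a double-bonded chain carbon bound to a double-bonded chain carbon. Neither measured step bears on this change: one swaps a halogen for another halogen, the other adds a halogen to the shared core, and both leave the 1H-indol-3-yl group in place. Nothing measured here speaks to its removal. Without a step to lean on, compound 4 is expected to stay near compound 1, so the expected step is no change at the digits printed from compound 1 to compound 4 (within the scatter). The estimate for compound 4 is 10000 nM, with a wide range from 3000 nM to 40000 nM.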

Compound 4, concentration for 50% growth inhibition: 50000 nM
For compound 4 the middle estimate is 5.0-fold (0.70 log units) below the measured one, outside the stated range (above it).
By their numbers in this assay, from the lowest: compound 3; then compounds 1 and 2 (each within the scatter of the next); then compound 4.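

In this assay, within the data shown here, the step is a 5.0-fold higher number from compound 1 to compound 4 (0.70 log units; beyond the scatter), and it is the first measured change to the 1H-indol-3-yl group, which all the earlier compounds retain. At this position, 4-methoxyphenyl therefore does not serve as an equal replacement for 1H-indol-3-yl. The leaving group carries a hydrogen-bond donor and the entering group a hydrogen-bond acceptor, but this single step cannot show which difference matters, and no measurement here offers an explanation.

From the compounds shown here alone, it remains open whether a plain phenyl group, or a methyl group on the indole nitrogen, would track compound 1 or compound 4. Also open, going by these compounds, is whether the chloro that separates compound 3 from compound 1 would lower the number with 4-methoxyphenyl in place.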